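The source may hold more compounds than are shown below. What is called first, only, known or untested is meant among the compounds shown, and "the series" means these compounds.

Compound 1 `CCc1cccc2c(OC)c(-c3occ(C)c3C(=O)NC)ccc12` — > 10 ug/mL
Compound 2 `CCc1cccc2c(OC)c(-c3occ(C)c3COC)ccc12` — > 10 ug/mL

In a functional assay on DU-145 cells (Homo sapiens) for cytotoxicity, read by MTT assay, with a stated time of 72 h (on this read-out lower numbers stand for an effect already at smaller amounts and higher numbers for an effect only at larger amounts of compound), compound 1 gives only a limit, > 10 ug/mL. In this assay compound 2 likewise gives only a limit, > 10 ug/mL. The step that the two limits leave unreadable from compound 1 to compound 2 therefore cannot be sized, since both values sit at the limit of > 10 ug/mL in this assay, at which 2 of the 2 values shown sit. Compound 3 `CCOCc1c(C)coc1-c1ccc2c(CC)cccc2c1OC` differs from compound 2 by methyl in place of hydrogen on a saturated chain carbon bound to an oxygen on a saturated carbon. Among the compounds with values here, the single measured step, that between the methylcarbamoyl compound and the methoxymethyl compound, is the only one bearing on this change, and it is unreadable; it shows merely that exchanging the whole substituent left the read-out at the limit. No step beyond the scatter is therefore expected in this assay from compound 2 to compound 3, and the estimated step is a step that the limit leaves unreadable from compound 2 to compound 3. Compound 3 is expected at about 15 ug/mL, with a range from 5 ug/mL to 40 ug/mL, and most probably the assay would again report only a limit.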

Compound 3, concentration for half-maximal effect: > 10 ug/mL
Compound 3: a limit, no number; the forecaster's own chance of this, stated with the estimate: 75%; the middle value lies beyond the limit too.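

Compound 3 gives only a limit in this assay, > 10 ug/mL. Within the data shown here, no step among compound 1, compound 2 and compound 3 can be read: the limit of > 10 ug/mL in this assay, at which 3 of the 3 values shown sit. The compounds shown leave open where the true values of all three lie, and whether methoxymethyl to ethoxymethyl changes the read-out at all.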